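Removing one thiazole methyl from a symmetric bivalent agonist

This account rests on a few compounds, and the source may have more. Where it says the series, first, only, none or still open, it means among the compounds named here.

Three compounds of this series have been run in an in vitro functional assay on Sf9 cells for agonist activity at histamine H2 receptor (Homo sapiens); a higher number here means a larger maximal response, a lower number a smaller maximal response. Compound 1 `Cc1nc(N)sc1CCCN/C(N)=N/C(=O)CCCCCCCC(=O)/N=C(\N)NCCCc1sc(N)nc1C` gives 0.48. Compound 2 `Cc1nc(N)sc1CCCN/C(N)=N/C(=O)CCCCCCCCC(=O)/N=C(\N)NCCCc1sc(N)nc1C` gives 0.53, a gap to compound 1 that lies within the scatter, so the two cannot be told apart. Compound 3 `N/C(=N\C(=O)CCCCCCCCCCCCCCC(=O)/N=C(\N)NCCCc1cnc(N)s1)NCCCc1cnc(N)s1` gives 0.14, a gap to compound 2 that lies beyond the scatter.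

Compound 4 `Cc1nc(N)sc1CCCN/C(N)=N/C(=O)CCCCCCCCC(=O)/N=C(\N)NCCCc1cnc(N)s1` has not yet been measured in this assay. It differs from compound 2 in one place, (hydrogen in place of methyl on an aromatic carbon), so that one end reads 2-amino-1,3-thiazol-5-yl instead of 2-amino-4-methyl-1,3-thiazol-5-yl while the other end keeps its methyl. Among the compounds with values here, no measured pair differs by this change alone. Compound 3 carries the unmethylated ring at both ends together with a longer chain, so its value of 0.14 does not isolate the change. A step from compound 2 to compound 4 of a number 0.11 lower from compound 2 to compound 4 (beyond the scatter) is expected, a modest drop that may or may not clear the scatter. For compound 4 the expected value in this assay is 0.42, with a range from 0.27 to 0.56.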

Compound 4, intrinsic activity: the largest response reached, as a fraction of the reference agonist's: 0.75
The estimate for compound 4 lay 0.33 below the measured number, outside the stated range (above it).
By their numbers in this assay, from the lowest: compound 3; then compounds 1 and 2 (each within the scatter of the next); then compound 4.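

In this assay this change can now be read on its own, and hydrogen in place of methyl at one end of the chain gives a number 0.22 higher from compound 2 to compound 4 (beyond the scatter) with the other end unchanged. On this aromatic carbon the methyl at that end is therefore not needed for the maximal response of compound 2, and the unsymmetric compound 4 shows that the two ends need not match to reach a larger one. No measurement on hand accounts for the rise.

On these data alone, it remains open whether removing the second methyl on the same chain would add to this step or reverse it, since compound 3 also carries a longer chain. Also open, as far as these compounds go, is how an ethyl group or a chlorine atom on this ring carbon would compare with hydrogen and methyl.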